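The source may report more compounds than this note shows. Statements on the series, on what has been measured and on what is new or still open speak of the compounds shown alone.

Measured so far:
- compound 2, `C#CCN(C)CCCCOc1ccc2ccc(=O)oc2c1`: 3280 nM
- compound 3, `C#CCN(CCCOc1ccc2ccc(=O)oc2c1)Cc1ccc(C(C)C)cc1`: 77400 nM
- compound 1, `C#CCN(CCCOc1ccc2ccc(=O)oc2c1)Cc1ccc(C)cc1`: 116000 nM

In an ADME assay on isolated protein for inhibition of Amine oxidase [flavin-containing] A (Homo sapiens), read by fluorescence and Amplex Red, with stated times of 15 min and 20 min (a higher number here means a weaker inhibitor, a lower number a stronger inhibitor), compound 2 gives the lowest number of the three; compound 3 and compound 1 both sit at higher numbers, and both gaps lie beyond the scatter. Going by the values given here, the only step measured within one change, a 1.5-fold lower number from compound 1 to compound 3 (0.18 log units; within the scatter), lies within the scatter.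

Compound 4, `C#CCN(CCCCOc1ccc2ccc(=O)oc2c1)Cc1ccc(F)c(F)c1`, differs from compound 2 by 3,4-difluorophenyl in place of hydrogen on a saturated chain carbon bound to an amine nitrogen. Among the compounds with values here, no measured step covers this change directly. Compounds 1 and 3 carry a substituted benzyl group on the amine nitrogen in place of methyl, but on a shorter linking chain, so their gap to compound 2 mixes two changes and bears on the step only loosely. What the pair of compounds 1 and 3 does show is that the aromatic substituent itself moved the number little.

Compound 4 is therefore expected to give a clearly higher number than compound 2, with the step of a 9.1-fold higher number from compound 2 to compound 4 (0.96 log units; beyond the scatter) estimated as beyond the scatter. For compound 4 the expected value is 30000 nM, in the range 5000 nM to 150000 nM.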

Compound 4, half-maximal inhibitory concentration: 93200 nM
Beside the measured number, compound 4's estimate is 3.1-fold (0.49 log units) below it, within the range that was stated.
By their numbers in this assay, from the lowest: compound 2; then compounds 3, 4 and 1 (each within the scatter of the next).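

Working from the pair with the linking chain held the same, the change from methyl to 3,4-difluorobenzyl alone gives a 28-fold higher number from compound 2 to compound 4 (1.45 log units; beyond the scatter) in this assay. Going by these compounds alone, the earlier gaps to compound 2 mixed this group change with a change in chain, so this is the first clean reading of the position: a hydrogen replaced by 3,4-difluorophenyl on the saturated chain carbon bound to the amine nitrogen costs much inhibition, with no chain change needed. No supporting measurement bears on why this step is so large.

As far as these compounds go, whether the loss follows from the ring itself or from its fluorines stays open, as does how an unsubstituted benzyl, an ethyl or a cyclopropylmethyl group would read in this place. From the compounds shown here alone, how far the length of the linking chain counts by itself also remains open.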